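The compounds below may be only part of what the source reports. "The series", "measured", "known", "first", "only" and "open" are said of these compounds alone.

Working notes on the series. Compound 1 `Oc1ccccc1/C=N/c1nnc(SCc2nnc(-c3ccccc3)o2)s1` gives 4110 nM in a functional assay on A549 cells (Homo sapiens) for inhibition, read by CCK-8 assay; on this read-out lower numbers stand for stronger inhibition and higher numbers for weaker inhibition. Compound 2 `Oc1ccccc1/C=N/c1nnc(SCc2nnc(-c3ccc(F)cc3)o2)s1` gives 20100 nM in this assay, a step of a 4.9-fold higher number from compound 1 to compound 2 (0.69 log units; beyond the scatter). Compound 3 `Cc1ccccc1-c1nnc(CSc2nnc(/N=C/c3ccccc3O)s2)o1` gives 7850 nM in this assay. Among the three numbers so far, compound 3 stands second highest, nearest to compound 1 and furthest from compound 2. The step of a 1.9-fold higher number from compound 1 to compound 3 (0.28 log units; within the scatter) is within the scatter, so compounds 1 and 3 cannot be ordered against each other; the step of a 2.6-fold lower number from compound 2 to compound 3 (0.41 log units; beyond the scatter) is a modest one.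

Compound 4 `Cc1cccc(-c2nnc(CSc3nnc(/N=C/c4ccccc4O)s3)o2)c1` differs from compound 3 by 3-methylphenyl in place of 2-methylphenyl on an aromatic carbon. The two share the same atoms, joined differently. Among the measured compounds shown here, no measured step addresses where the methyl sits on the ring, so the bearing of the measured steps is indirect. The step of a 1.9-fold higher number from compound 1 to compound 3 (0.28 log units; within the scatter) shows that the methyl itself changes little from the unsubstituted ring, and the step of a 2.6-fold lower number from compound 2 to compound 3 (0.41 log units; beyond the scatter) is only modest. A rearrangement of the same atoms gives no ground to expect more than this. In this assay the step from compound 3 to compound 4 is therefore expected to be a 1.1-fold lower number from compound 3 to compound 4 (0.05 log units; within the scatter), not beyond the scatter. Compound 4 is estimated at 7000 nM, with a range from 3000 nM to 16000 nM.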

Compound 4, half-maximal inhibitory concentration: 24300 nM
Compound 4: middle estimate off by 3.5-fold (0.54 log units), on the low side; the measured number lies above the stated range.
By their numbers in this assay, from the lowest: compounds 1 and 3 (each within the scatter of the next); then compounds 2 and 4 (each within the scatter of the next).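

Where the methyl sits on the phenyl ring matters in this assay: with the atoms unchanged, the shift from 2-methylphenyl to 3-methylphenyl gives a 3.1-fold higher number from compound 3 to compound 4 (0.49 log units; beyond the scatter), whereas the earlier compounds showed only the 2-methylphenyl group, which could not be ordered against the unsubstituted phenyl ring. Methyl in place of hydrogen is therefore not neutral at every place on this ring, since the 3-methylphenyl group gives a 5.9-fold higher number from compound 1 to compound 4 (0.77 log units; beyond the scatter), a modest step beyond the scatter, while its comparison with the 4-fluorophenyl group gives a 1.2-fold higher number from compound 2 to compound 4 (0.08 log units; within the scatter), so those two groups cannot be ordered against each other. No measurement shown here accounts for this dependence on place.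

From the compounds shown here alone, it remains open whether a methoxy group or an amine on the phenyl ring would show the same dependence on place, and whether the fluoro of compound 2 would shift with its place as the methyl does. The rest of the shared core stays the same in all the compounds shown, so they do not tell whether the step between the two methylphenyl groups would hold with another group elsewhere on the core.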